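Piperidine amine variation on a tryptamine-triazole core

The source may report more compounds than this note shows. Statements on the series, on what has been measured and on what is new or still open speak of the compounds shown alone.

In an assay on CHO cells for displacement of a labelled ligand from 5-hydroxytryptamine receptor 1D (Homo sapiens) (a lower number here means a stronger inhibitor, a higher number a weaker inhibitor), compound 1 `CN(C1CCN(CCCc2c[nH]c3ccc(-n4cnnc4)cc23)CC1)S(=O)(=O)c1ccccc1` gives 1.5 nM, while compound 2 `C[C@@H](NC1CCN(CCCc2c[nH]c3ccc(-n4cnnc4)cc23)CC1)c1ccccc1` gives 0.4 nM, the lowest of the two numbers; the step of a 3.8-fold lower number from compound 1 to compound 2 (0.57 log units; beyond the scatter) lies beyond the scatter. Compound 3 `CN(Cc1ccccc1)CC1CCN(CCCc2c[nH]c3ccc(-n4cnnc4)cc23)CC1` carries (benzyl(methyl)amino)methyl in place of (1-phenylethyl)amino on a saturated ring carbon. Among the measured compounds shown here, only the step from compound 1 to compound 2 bears on this change, and it concerned the same ring carbon; it does not cover the inserted methylene or the loss of the amine hydrogen. A small rise in this assay, a 2.5-fold higher number from compound 2 to compound 3 (0.40 log units; beyond the scatter), is expected, not clearly beyond the scatter. Compound 3 is estimated at 1 nM, range 0.3 nM to 3.5 nM.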

Compound 3, half-maximal inhibitory concentration: 0.9 nM
The estimate for compound 3 lay 1.1-fold (0.05 log units) above the measured number, within the range that was stated.
By their numbers in this assay, from the lowest: compound 2; then compounds 3 and 1 (each within the scatter of the next).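

In this assay the saturated ring carbon also accepts (benzyl(methyl)amino)methyl, with one more heavy atom and no hydrogen-bond donor in the group, at the modest cost of a 2.3-fold higher number from compound 2 to compound 3 (0.35 log units; beyond the scatter). Against the sulfonyl-bearing group, a 1.7-fold lower number from compound 1 to compound 3 (0.22 log units; within the scatter), so methyl(phenylsulfonyl)amino and (benzyl(methyl)amino)methyl cannot be ranked here. No available data explain either step.

On these data alone, because the methylene and the amine hydrogen change together in compound 3, their separate contributions remain open. A (benzylamino)methyl group on the same ring carbon would separate them, while the opposite configuration of (1-phenylethyl)amino remains a further open comparison.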